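The source may hold more compounds than are shown below. What is called first, only, known or untested is meant among the compounds shown, and "the series" means these compounds.

Within this small set compound 3 `CC1(C)[C@H]2CC[C@]1(C)N(Cc1cn(-c3cccc(O)c3)nn1)C(=O)C2` stands at the weak end: in a functional assay on OVCAR-3 cells (Homo sapiens) for inhibition, read by MTT assay, with a stated time of 24 h (a higher number here means a weaker inhibitor, a lower number a stronger inhibitor), compound 3 gives 370 nM, whereas compound 2 `CC1(C)[C@H]2CC[C@]1(C)N(Cc1cn(-c3ccccc3)nn1)C(=O)C2` gives 50 nM and compound 1 `CC1(C)[C@H]2CC[C@]1(C)N(Cc1cn(-c3ccc(Cl)cc3)nn1)C(=O)C2` gives 160 nM. Compound 4 `CC1(C)[C@H]2CC[C@]1(C)N(Cc1cn(-c3cccc(C#N)c3)nn1)C(=O)C2` differs from compound 3 by cyano in place of hydroxy on an aromatic carbon. Among the measured compounds shown here, no measured step puts a cyano group on this ring, but two steps bear on the change: a 7.4-fold higher number from compound 2 to compound 3 (0.87 log units; beyond the scatter), and a 3.2-fold lower number from compound 1 to compound 2 (0.51 log units; beyond the scatter). Taking the hydroxy away is thus expected to bring the number down toward compound 2, while a different substituent in its place, judging from the chloro of compound 1, may hold part of that back. In this assay compound 4 is therefore expected to give about 110 nM, in a range of 40 nM to 300 nM, an expected move of a 3.4-fold lower number from compound 3 to compound 4 (0.53 log units; beyond the scatter).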

Compound 4, half-maximal inhibitory concentration: 230 nM
Estimate against measurement, compound 4: 2.1-fold (0.32 log units) below, and the stated range covers the measured number.
By their numbers in this assay, from the lowest: compound 2; then compounds 1, 4 and 3 (each within the scatter of the next, the first and the last beyond it).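

In this assay cyano in place of hydroxy gives a 1.6-fold lower number from compound 3 to compound 4 (0.21 log units; within the scatter) and so does not separate the two groups, even though the hydrogen-bond donor leaves. Cyano in place of hydrogen gives a 4.6-fold higher number from compound 2 to compound 4 (0.66 log units; beyond the scatter) so a second group on this carbon, besides hydroxy, gives a higher number than hydrogen. The step of a 1.4-fold higher number from compound 1 to compound 4 (0.16 log units; within the scatter) does not separate 3-cyanophenyl from 4-chlorophenyl either.

From the compounds shown here alone, whether an amine or a methoxy group on this carbon would also give a higher number than compound 2 remains open. Nothing available gives a cause for these steps.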